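This account rests on a few compounds, and the source may have more. Where it says the series, first, only, none or still open, it means among the compounds named here.

Measured compounds:
Compound 1, `CN1CCN(Cc2ccc(NC(=O)Nc3ccc4ncnc(Nc5ccc(F)c(F)c5)c4c3)cc2)CC1`, in a functional assay on A549 cells (Homo sapiens) for antiproliferative activity, read by MTT assay, with a stated time of 72 h; on this read-out lower numbers stand for stronger inhibition and higher numbers for weaker inhibition: compound 1 gives only a limit, > 10000 nM.
Compound 2, `O=C(Nc1ccc(CN2CCCC2)cc1)Nc1ccc2ncnc(Nc3cccc(C(F)(F)F)c3)c2c1`, in this assay: compound 2 gives 830 nM.

Among the measured compounds shown here, compound 2 holds the only true number among the two values shown, since the other sits at the limit of > 10000 nM in this assay, at which 1 of the 2 values shown sits, and is a limit rather than a measurement. Compound 3, `CN1CCN(c2ccc(NC(=O)Nc3ccc4ncnc(Nc5cccc(C(F)(F)F)c5)c4c3)cc2)CC1`, has not yet been tested. It differs from compound 2 in one place: 4-methylpiperazin-1-yl in place of (pyrrolidin-1-yl)methyl on an aromatic carbon. Compound 1 carries a related 4-methylpiperazine group but also differs from compound 2 elsewhere, so it offers no isolated reading of this change. For the measured compounds named here, with no measured step to lean on, the author expects the change to cost some activity, with the step from compound 2 to compound 3 estimated as a 1.8-fold higher number from compound 2 to compound 3 (0.26 log units; within the scatter), though a value within the usual scatter would not surprise. Compound 3 is therefore estimated at 1500 nM, with a likely range from 400 nM to 8000 nM.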

Compound 3, half-maximal inhibitory concentration: 2760 nM
Compound 3: the middle estimate sits 1.8-fold (0.26 log units) below what was measured; low and high end bracket the measured number.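

Among the compounds shown here, the first isolated reading of this position comes from the swap of (pyrrolidin-1-yl)methyl for 4-methylpiperazin-1-yl, on an aromatic carbon para to a large group. In this assay it gives a 3.3-fold higher number from compound 2 to compound 3 (0.52 log units; beyond the scatter), so the position responds to this change by more than the usual scatter, though the modest step still leaves compound 3 with a true number rather than a limit. Nothing measured here bears on why the number rises.

The compounds shown leave open whether the step follows from the ring that enters or from the change in how that ring is attached, since both change together. A pyrrolidin-1-yl group placed directly on the aromatic carbon, or a morpholin-4-yl group there, would be needed to tell these readings apart.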